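The source may hold more compounds than are shown below. What is called first, only, known or untested is meant among the compounds shown, and "the series" means these compounds.

Values in an ADME assay on MT4 cells (Homo sapiens) for cytotoxicity, read by MTT assay, with a stated time of 4 days (a higher number here means that more compound is tolerated, a lower number that less compound is tolerated), so far:
- compound 1 `Nc1ccc2oc(-c3ccc(C(F)(F)F)cc3)cc(=O)c2c1`: 273000 nM
- compound 2 `Nc1ccc2oc(-c3ccc(C(F)(F)F)cc3)c(O)c(=O)c2c1`: 3900 nM
- compound 3 `COc1c(-c2ccc(F)cc2)oc2ccc(N)cc2c1=O`: 141000 nM

Compound 3, at 141000 nM, lies within the scatter of compound 1 and far higher than compound 2. Next is compound 4 `COc1c(-c2ccc(C(F)(F)F)cc2)oc2ccc(N)cc2c1=O`, with trifluoromethyl in place of fluoro on an aromatic carbon. Going by the values given here, no measured step covers this change. The only one, a 70-fold lower number from compound 1 to compound 2 (1.85 log units; beyond the scatter), is large but concerns hydroxy in place of hydrogen, so it does not bear directly. Compound 1, which also carries trifluoromethyl, gives 273000 nM, so no shift beyond the scatter is expected in this assay. The expected step is a 1.2-fold higher number from compound 3 to compound 4 (0.08 log units; within the scatter). Compound 4 is estimated at 170000 nM, within an expected range of 60000 nM to 400000 nM.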

Compound 4, half-maximal cytotoxic concentration: 290000 nM
The estimate for compound 4 lay 1.7-fold (0.23 log units) below the measured number, within the range that was stated.
By their numbers in this assay, from the lowest: compound 2; then compounds 3, 1 and 4 (each within the scatter of the next, the first and the last beyond it).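

Going by these compounds alone, with the methoxy in place, trifluoromethyl in place of fluoro gives a 2.1-fold higher number from compound 3 to compound 4 (0.31 log units; beyond the scatter) in this assay and is the first step measured at this position. Methoxy in place of hydrogen gives a 1.1-fold higher number from compound 1 to compound 4 (0.03 log units; within the scatter) while methyl on the oxygen gives a 74-fold higher number from compound 2 to compound 4 (1.87 log units; beyond the scatter) and so, among these compounds, only the free hydroxy stands apart. Nothing measured on these compounds accounts for these steps.

Open, going by these compounds, is whether a carboxylic acid or an amine in place of trifluoromethyl keeps the number this high. Also open, on these data alone, is whether a longer chain on the oxygen matches methyl.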